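This account rests on a few compounds, and the source may have more. Where it says the series, first, only, none or still open, it means among the compounds named here.

Measured so far:
- Compound 1, `COc1ccc(CCCN2CCC(COC(c3ccc(Cl)cc3)c3ccc(Cl)cc3)CC2)cc1`, in a functional assay on cells (T-cell line, Homo sapiens) for inhibition (a higher number here means a weaker inhibitor, a lower number a stronger inhibitor), gives 1100 nM.
- Compound 2, `COc1ccc(CCCN2CCC(CCC(c3ccccc3)c3ccccc3)CC2)cc1`, in this assay gives 200 nM.
- Compound 3, `CCN1CCC(COC(c2ccccc2)c2ccccc2)CC1`, in this assay gives > 20000 nM, which is a limit of the assay and not a number.

Compound 3 therefore stands at the weak end of what has been measured, at the limit of > 20000 nM in this assay, at which 1 of the 3 values shown sits. Compounds 1 and 2 each carry a long chain on the ring nitrogen ending in a methoxyphenyl group, and both give a real number in this assay. Compound 3 carries only an ethyl on that nitrogen and gives no number at all.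

Compound 4, `COc1ccc(/C=C/CN2CCC(COC(c3ccccc3)c3ccccc3)CC2)cc1`, has not yet been measured in this assay. It differs from compound 3 as follows: 2-(4-methoxyphenyl)ethenyl in place of methyl on a saturated chain carbon bound to an amine nitrogen in a ring. With this change compound 4 comes to resemble compounds 1 and 2, whose values show that a chain of this kind on the ring nitrogen goes together with measurable inhibition.

For the step from compound 3 to compound 4 in this assay a large move toward stronger inhibition is expected, well beyond the usual scatter, of about an at least 13-fold lower number from compound 3 to compound 4 (1.12 log units; beyond the scatter). Compound 4 is thus expected to give about 1500 nM, most likely somewhere between 300 nM and 8000 nM.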

Compound 4, half-maximal inhibitory concentration: 4300 nM
Beside the measured number, compound 4's estimate is 2.9-fold (0.46 log units) below it, and the stated range covers the measured number.
By their numbers in this assay, from the lowest: compound 2; then compound 1; then compound 4. At a limit, above all of these: compound 3.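

In this assay, putting 2-(4-methoxyphenyl)ethenyl in place of methyl on a saturated chain carbon bound to an amine nitrogen in a ring gives an at least 4.6-fold lower number from compound 3 to compound 4 (0.66 log units; beyond the scatter). Compounds 1 and 2 could only hint at the value of a long group at this position, since each differs from compound 3 in more than one place, whereas compound 3 and compound 4 differ in this one place alone, so the link between this change and stronger inhibition now rests on a direct comparison. The printed step gives only the least the change can be worth, because compound 3 has no exact value: the limit of > 20000 nM in this assay, at which 1 of the 4 values shown sits.

The compounds shown leave open which part of the added group goes with the stronger inhibition: the aromatic ring, the methoxy group or the double bond. A fully saturated chain, an unsubstituted phenyl ring at the chain end, or a hydroxyl group or a dimethylamino group in place of the methoxy, each on this same core, would begin to separate these parts.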